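Triazole series: aryl substituent changes and glycine transporter binding

This account rests on a few compounds, and the source may have more. Where it says the series, first, only, none or still open, it means among the compounds named here.

Measured so far in an assay on C6 glioma cells for displacement of a labelled ligand from sodium- and chloride-dependent glycine transporter 1 (Rattus norvegicus), read by scintillation counting, with stated times of 30 min and 10 min; a higher number here means a weaker inhibitor, a lower number a stronger inhibitor:
- compound 1 `CCc1nnc(-c2ccc(-c3ccccc3)cc2)n1-c1ccccc1C` gives 300 nM
- compound 2 `CCc1nnc(-c2ccc(-c3ccccc3)cc2)n1-c1cccc(COC)c1C` gives 2400 nM
- compound 3 `CCc1nnc(-c2ccc(-c3ccccc3)cc2)n1-c1cccc(CN(C)C)c1C` gives 29000 nM

Compound 3 holds the highest number of the three in this assay; the nearest is compound 2, since the step of a 12-fold higher number from compound 2 to compound 3 (1.08 log units; beyond the scatter) was large, and the furthest is compound 1, since the step of a 97-fold higher number from compound 1 to compound 3 (1.99 log units; beyond the scatter) was larger still. Compound 4 `CCc1nnc(-c2ccc(-c3ccccc3)cc2)n1-c1cccc(C(=O)OC)c1C` carries the change (methoxycarbonyl in place of (dimethylamino)methyl on an aromatic carbon). Among the compounds with values here, two measured steps bear on it. The step of an 8.0-fold higher number from compound 1 to compound 2 (0.90 log units; beyond the scatter) shows that an ether-bearing chain on the same aromatic carbon costs a modest amount against hydrogen. The step of a 12-fold higher number from compound 2 to compound 3 (1.08 log units; beyond the scatter) shows that swapping that ether for a dimethylamino group on the chain carbon costs a further large amount. The entering methoxycarbonyl, with its two oxygen acceptors and no nitrogen, looks closer to the methoxymethyl of compound 2 than to the group it replaces, so a large step downward in this assay is expected, roughly undoing the second of those steps. For compound 4 the expected step is a 9.7-fold lower number from compound 3 to compound 4 (0.99 log units; beyond the scatter). Compound 4 is therefore estimated at 3000 nM, within a range of 800 nM to 12000 nM.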

Compound 4, half-maximal inhibitory concentration: 5100 nM
Estimate against measurement, compound 4: 1.7-fold (0.23 log units) below; the measured number falls inside the stated range.
By their numbers in this assay, from the lowest: compound 1; then compound 2; then compound 4; then compound 3.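

In this assay, methoxycarbonyl on this aromatic carbon, ortho to a methyl group, recovers only part of the loss seen with (dimethylamino)methyl (a 5.7-fold lower number from compound 3 to compound 4 (0.75 log units; beyond the scatter)) and remains well short of hydrogen (a 17-fold higher number from compound 1 to compound 4 (1.23 log units; beyond the scatter)). It also gives a modestly higher number than methoxymethyl (a 2.1-fold higher number from compound 2 to compound 4 (0.33 log units; beyond the scatter)), so the two groups without nitrogen lie nearer each other than either lies to (dimethylamino)methyl, while all three groups give higher numbers than hydrogen. No supporting data accompany these values to account for this order.

A carboxylic acid, a primary amide or a hydroxymethyl group on this carbon would test whether the order extends beyond these groups. Going by these compounds, whether any group here can match hydrogen, and whether the order holds on other aromatic carbons, remains open.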